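The compounds below may be only part of what the source reports. "The series", "measured", "known", "first", "only" and "open" are said of these compounds alone.

Measured in a functional assay on NCI-H460 cells (Homo sapiens) for cytotoxicity, read by MTT assay, with a stated time of 72 h; a lower number here means a stronger inhibitor, a higher number a weaker inhibitor:
Compound 1 `O=c1[nH]/c(=C\c2nc[nH]c2C2CC2)c(=O)[nH]/c1=C\c1cccc(Oc2ccc(F)cc2)c1`: 15.2 nM
Compound 2 `O=c1[nH]/c(=C\c2ccc(Cl)o2)c(=O)[nH]/c1=C\c1cccc(Oc2ccc(F)cc2)c1`: 180 nM
Compound 3 `O=c1[nH]/c(=C\c2ccc(CO)o2)c(=O)[nH]/c1=C\c1cccc(Oc2ccc(F)cc2)c1`: 41.5 nM

Compound 3 stands in the middle of these three numbers, with compound 1 lower and compound 2 higher. Compound 4 `O=c1[nH]/c(=C\c2cc3ccccc3o2)c(=O)[nH]/c1=C\c1cccc(Oc2ccc(F)cc2)c1` has not yet been measured. It differs from compound 3 in one place: 1-benzofuran-2-yl in place of 5-(hydroxymethyl)furan-2-yl on a double-bonded chain carbon bound to an aromatic carbon. In other words, 1-benzofuran-2-yl replaces 5-(hydroxymethyl)furan-2-yl on a double-bonded chain carbon bound to an aromatic carbon. Within the data shown here, no measured compound carries 1-benzofuran-2-yl, so the guidance is indirect. Changes at this same place gave a 2.7-fold higher number from compound 1 to compound 3 (0.44 log units; beyond the scatter) and a 12-fold higher number from compound 1 to compound 2 (1.07 log units; beyond the scatter). The closest comparison is a 4.3-fold lower number from compound 2 to compound 3 (0.64 log units; beyond the scatter), where hydroxymethyl replaces chloro on the furan. This shows that this assay responds to what the furan carries. Compound 4 has no hydroxymethyl, and neither does compound 2, which gives 180 nM. A modest rise is therefore expected, an estimated 2.4-fold higher number from compound 3 to compound 4 (0.38 log units; beyond the scatter). For compound 4 the estimated value is 100 nM, with an expected range of 30 nM to 330 nM.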

Compound 4, half-maximal inhibitory concentration: 347 nM
For compound 4 the middle estimate is 3.5-fold (0.54 log units) below the measured one, and the stated range ends below it.
By their numbers in this assay, from the lowest: compound 1; then compound 3; then compounds 2 and 4 (each within the scatter of the next).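

Placing 1-benzofuran-2-yl where 5-(hydroxymethyl)furan-2-yl stood in this assay gives a clear loss (an 8.4-fold higher number from compound 3 to compound 4 (0.92 log units; beyond the scatter)), so adding a six-membered carbon ring to the furan brings no gain at this place. Against the 5-chlorofuran-2-yl group, the result is a 1.9-fold higher number from compound 2 to compound 4 (0.29 log units; within the scatter), so these two groups, neither of which carries hydroxymethyl, cannot be told apart here, while compound 3 keeps a lower number than both. The 5-cyclopropyl-1H-imidazol-4-yl group still gives the lowest number of the set, now also against the benzofuran (a 23-fold higher number from compound 1 to compound 4 (1.36 log units; beyond the scatter)).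

Nothing available explains why these groups differ. As far as these compounds go, it also remains open whether an amine or a carboxylic acid in place of the hydroxymethyl on the furan, or a longer chain ending in a hydroxyl, would lower the number further.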